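Working notes: bromo entering the anilino ring

The compounds below may be only part of what the source reports. "The series", "measured", "known", "first", "only" and "open" are said of these compounds alone.

Measured compounds in a functional assay on NCI-H1975 cells (Homo sapiens) for inhibition, read by MTT assay, with a stated time of 72 h; on this read-out higher numbers stand for weaker inhibition and lower numbers for stronger inhibition:
compound 1 `O=C(CSc1nc(Nc2ccccc2)c2ccccc2n1)Nc1ccccc1Cl` gives 9610 nM
compound 2 `C=CC(=O)Nc1cccc(NC(=O)CSc2nc(Nc3ccccc3)c3ccccc3n2)c1` gives 8120 nM
compound 3 `O=C(CSc1nc(Nc2ccccc2)c2ccccc2n1)Nc1ccc(Cl)cc1Cl` gives 8410 nM

The three numbers sit close together. The step of a 1.2-fold lower number from compound 1 to compound 2 (0.07 log units; within the scatter) and the step of a 1.1-fold lower number from compound 1 to compound 3 (0.06 log units; within the scatter) are both within the scatter, as is the step of a 1.0-fold higher number from compound 2 to compound 3 (0.02 log units; within the scatter). Compound 2 is therefore not separated from compound 1 or compound 3 beyond the scatter, and no ordering among the three can be read from this assay.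

Compound 4 `C=CC(=O)Nc1cccc(NC(=O)CSc2nc(Nc3ccccc3Br)c3ccccc3n2)c1` differs from compound 2 by bromo in place of hydrogen on an aromatic carbon, that is, on the phenyl of the anilino group, ortho to a large group, anilino becoming (2-bromophenyl)amino. Among the measured compounds shown here, none of the measured steps touches this part of the shared core: the steps from compound 1 exchange the amide-side aryl group, and the step from compound 1 to compound 3 places chloro on that amide-side ring, not on the anilino ring. For the measured compounds named here, there is thus no measured step that bears directly on the change to compound 4. With every measured step within the scatter, no shift beyond the scatter is expected for compound 4 in this assay, and the step of a 1.0-fold lower number from compound 2 to compound 4 (0.01 log units; within the scatter) is estimated to stay within it. For compound 4 the expected value is 8000 nM, in the range 3000 nM to 25000 nM.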

Compound 4, half-maximal inhibitory concentration: 19300 nM
For compound 4 the middle estimate is 2.4-fold (0.38 log units) below the measured one; measured number inside the range.
By their numbers in this assay, from the lowest: compounds 2, 3, 1 and 4 (each within the scatter of the next, the first and the last beyond it).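

In this assay, the anilino ring of the shared core moves the read-out where the exchanges on the amide side did not: a 2.4-fold higher number from compound 2 to compound 4 (0.38 log units; beyond the scatter) is the only step among these compounds beyond the scatter, and it runs toward weaker inhibition, though it remains modest. At this place, ortho to a large group, turning anilino into (2-bromophenyl)amino therefore carries a measurable cost, so this ring is not as indifferent to change as the amide-side aryl groups have appeared so far. The compounds come with no measured information that could account for the shift.

Resting on a single substituent at a single place, the result leaves open whether a smaller fluoro or a methoxy at the same place would give a step of similar size, and whether bromo elsewhere on this ring would do the same. It also leaves open whether the same bromo change would carry over to the 2-chlorophenyl amide of compound 1 or the 2,4-dichlorophenyl amide of compound 3.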